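The source may report more compounds than this note shows. Statements on the series, on what has been measured and on what is new or still open speak of the compounds shown alone.

Of the compounds shown here, three sharing one core have so far been read in a functional assay on T47D cells (Homo sapiens) for inhibition, read by CCK-8 assay, with a stated time of 72 h, tested at 10 uM (on this read-out lower numbers stand for less inhibition of growth and higher numbers for more inhibition of growth at the one concentration tested), at the single concentration tested. There compound 1 (`CN(C)C(=O)c1cc2cnc(Nc3ccc(NC(=O)C4(C(=O)Nc5ccc(Cl)cc5)CC4)cc3)nc2n1C1CCCC1`) gives 95% of inhibition, compound 2 (`CN(C)C(=O)c1cc2cnc(Nc3ccc(NC(=O)C4(C(=O)Nc5ccc(Cl)c(C(F)(F)F)c5)CC4)cc3)nc2n1C1CCCC1`) gives 55.8% of inhibition and compound 3 (`Cc1ccc(NC(=O)C2(C(=O)Nc3ccc(Nc4ncc5cc(C(=O)N(C)C)n(C6CCCC6)c5n4)cc3)CC2)cc1`) gives 99.6% of inhibition. Compound 3 and compound 1 lie within the scatter of each other at the top of this small set, while compound 2 stands beyond the scatter from both.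

The next compound is compound 4 (`CN(C)C(=O)c1cc2cnc(Nc3ccc(NC(=O)C4(C(=O)Nc5ccc(C(F)(F)F)cc5)CC4)cc3)nc2n1C1CCCC1`), which differs from compound 3 by trifluoromethyl in place of methyl on an aromatic carbon, para to a large group (trifluoromethyl in place of methyl on an aromatic carbon). Methyl in place of chloro left the number within the scatter (a number 4.6 percentage points higher from compound 1 to compound 3 (within the scatter)), so that step offers no warning. The only trifluoromethyl on hand is that of compound 2, which came with a large fall (a number 39.2 percentage points lower from compound 1 to compound 2 (beyond the scatter)), and the step back to the methyl compound is equally large (a number 43.8 percentage points higher from compound 2 to compound 3 (beyond the scatter)). Compound 2 carries trifluoromethyl together with chloro, whereas compound 4 carries it alone, so these steps are only a partial guide. A moderate fall is therefore expected, with the estimated change being a number 19.6 percentage points lower from compound 3 to compound 4 (beyond the scatter) in this assay with wide uncertainty. For compound 4 the estimated value is 80% with an expected range from 52% to 99% on this read-out.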

Compound 4, percent growth inhibition at one concentration: 94.9%
Compound 4: middle estimate off by 14.9 percentage points, on the low side, and the stated range covers the measured number.
By their numbers in this assay, from the lowest: compound 2; then compounds 4, 1 and 3 (each within the scatter of the next).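

In this assay, the place para to a large group tolerates trifluoromethyl on its own: a number 4.7 percentage points lower from compound 3 to compound 4 (within the scatter) and a number 0.1 percentage points lower from compound 1 to compound 4 (within the scatter), so methyl, chloro and trifluoromethyl cannot be told apart at this place. Trifluoromethyl is present on both sides of the one large step, a number 39.1 percentage points higher from compound 2 to compound 4 (beyond the scatter), which goes from 4-chloro-3-(trifluoromethyl)phenyl to 4-(trifluoromethyl)phenyl, so the low number of compound 2 does not follow from the presence of trifluoromethyl alone and instead stands with that whole substitution pattern. No measurement at hand accounts for this difference between compound 2 and compound 4.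

The compounds shown leave open whether the same tolerance would extend to a group of another kind at this place, such as an amine or a carboxylic acid, since all three groups read here are uncharged and none has a hydrogen-bond donor or acceptor. They also leave open whether a 3-chloro or 3-methyl group on the same phenyl would bring a fall like that of compound 2, and a single concentration cannot separate compound 1, compound 3 and compound 4 any further.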